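Replacing 3-fluorophenyl with 2-hydroxyphenyl in compound 1

The compounds below may be only part of what the source reports. "The series", "measured", "known", "first", "only" and "open" are said of these compounds alone.

Of the compounds shown here, two with a shared core have been measured in a functional assay on HOS cells (Homo sapiens) for inhibition, with a stated time of 72 h; a higher number here means a weaker inhibitor, a lower number a stronger inhibitor. Compound 1 `NC1CCC(Nc2nc(NCc3ccc(-c4cccc(F)c4)cc3)c3ncn(C4CCCC4)c3n2)CC1` gives 211 nM, the higher of the two numbers, which makes it the weaker inhibitor of the pair. Compound 2 `NC1CCC(Nc2nc(NCc3ccc(-c4ccsc4)nc3)c3ncn(C4CCCC4)c3n2)CC1` gives 89 nM, and this gap lies beyond the usual scatter of the measurement. The two compounds differ in more than one place, however, so the gap cannot be assigned to any single change.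

Compound 3 `NC1CCC(Nc2nc(NCc3ccc(-c4ccccc4O)cc3)c3ncn(C4CCCC4)c3n2)CC1` keeps the core of compound 1 and carries 2-hydroxyphenyl in place of 3-fluorophenyl on an aromatic carbon, para to a large group (2-hydroxyphenyl in place of 3-fluorophenyl on an aromatic carbon). For the measured compounds named here, no measured step covers this exchange, so the data offer no direct guide to it. The expectation therefore stays near the span set by compound 2 at 89 nM and compound 1 at 211 nM. In this assay a small shift towards a lower number is expected, not beyond the scatter, with the estimated step of a 1.4-fold lower number from compound 1 to compound 3 (0.15 log units; within the scatter). For compound 3 the estimated value is 150 nM, with an expected range from 50 nM to 450 nM.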

Compound 3, half-maximal inhibitory concentration: 1160 nM
Compound 3: the middle estimate sits 7.7-fold (0.89 log units) below what was measured, and the stated range ends below it.
By their numbers in this assay, from the lowest: compound 2; then compound 1; then compound 3.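

In this assay, the exchange gives a 5.5-fold higher number from compound 1 to compound 3 (0.74 log units; beyond the scatter). This is the first change at a single place among these compounds, and it shows that the number is sensitive to the group on this aromatic carbon, para to a large group, even when the ring stays the same size. The two groups match in heavy atoms, in their six-membered aromatic ring of carbon only and in carrying no net charge, so the step comes with the loss of fluorine and the arrival of oxygen with a hydrogen-bond donor and acceptor, and nothing measured here accounts for it.

The compounds shown move the substituent's identity and its place on the ring in one exchange, so the effect of the hydroxyl group cannot be separated from that of where it sits. As far as these compounds go, whether 3-hydroxyphenyl, 2-fluorophenyl, 2-methoxyphenyl or plain phenyl on this carbon would stay near compound 1 or near compound 3 remains open, as does whether the same exchange would have a comparable effect on the side chain carried by compound 2.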